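The compounds below may be only part of what the source reports. "The series", "measured", "known", "first", "only" and "open" are said of these compounds alone.

In a functional assay on DU-145 cells (Homo sapiens) for antiproliferative activity, read by MTT assay, with a stated time of 72 h (on this read-out higher numbers stand for weaker inhibition and lower numbers for stronger inhibition), compound 1 (`CCN(CC)CCCOc1cc2ncnc(Nc3ccc(C#N)cc3)c2cc1OC`) gives 68900 nM and compound 2 (`COc1cc2c(Nc3ccc(C#N)cc3)ncnc2cc1OCCCN1CCC(O)CC1`) gives 74900 nM. These two values sit within the scatter of each other, the step being a 1.1-fold higher number from compound 1 to compound 2 (0.04 log units; within the scatter). Compound 3 (`COc1cc2c(Nc3ccc(C#N)cc3)ncnc2cc1OCCCN1CCCCC1CCO`) is reported only as a limit, > 100000 nM. Its step from compound 2 is an at least 1.3-fold higher number from compound 2 to compound 3 (0.12 log units; that floor lies within the scatter).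

Compound 4 (`COc1cc2c(Nc3ccc(C#N)cc3)ncnc2cc1OCCCN1CCC(N(C)C)CC1`) has yet to be measured. It carries dimethylamino in place of hydroxy on a saturated ring carbon of compound 2, three ring bonds from the ring nitrogen: dimethylamino in place of hydroxy on a saturated ring carbon. Within the data shown here, no measured pair tests this exact exchange. The closest guides are the two exchanges of the group on the chain already cited, and neither shows a step beyond the scatter. On that basis, no step beyond the scatter is expected in this assay. The expected step is a 1.2-fold lower number from compound 2 to compound 4 (0.06 log units; within the scatter). Compound 4 is estimated at 65000 nM, with an expected range of 28000 nM to 100000 nM.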

Compound 4, half-maximal inhibitory concentration: 28300 nM
Estimate against measurement, compound 4: 2.3-fold (0.36 log units) above; low and high end bracket the measured number.
By their numbers in this assay, from the lowest: compound 4; then compounds 1 and 2 (each within the scatter of the next). At a limit, above all of these: compound 3.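

In this assay, the earlier exchanges of the group on the chain gave no step beyond the scatter, but dimethylamino in place of hydroxy on a saturated ring carbon, three ring bonds from the ring nitrogen, gives a 2.6-fold lower number from compound 2 to compound 4 (0.42 log units; beyond the scatter), so this position does respond to the group it carries. Compound 4 also stands apart from the other two compounds, with a 2.4-fold lower number from compound 1 to compound 4 (0.39 log units; beyond the scatter) and an at least 3.5-fold lower number from compound 3 to compound 4 (0.54 log units; beyond the scatter), each step modest or, for the last, at least modest. That last step has only a floor, since the value of compound 3 is a limit: the limit of > 100000 nM in this assay, at which 1 of the 4 values shown sits.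

The compounds shown leave open whether a methoxy group or a primary amine on the same ring carbon would give a similar step. They also leave open whether the step holds with a longer chain.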